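A few compounds are considered here, and "the series" means these few. Any claim that something is new, unique, unknown or untested is made for them only; others in the source may bear on it.

In an assay on isolated protein for displacement of a labelled ligand from prostaglandin E2 receptor EP3 subtype (Homo sapiens), read by scintillation counting, with a stated time of 2 h (on this read-out higher numbers stand for weaker inhibition and lower numbers for stronger inhibition), compound 1 `O=C(NC/C=C1\CCCc2cnn(Cc3ccc(Cl)cc3Cl)c21)NS(=O)(=O)c1ccc(Cl)cc1` gives 4 nM, and compound 2 `COc1ccc(S(=O)(=O)NC(=O)NC/C=C2\CCCc3cnn(Cc4ccc(Cl)cc4Cl)c32)cc1` gives 10 nM. Among the compounds with values here, the only single-point step among the measured compounds is a 2.5-fold higher number from compound 1 to compound 2 (0.40 log units; beyond the scatter). Compound 3 `CS(=O)(=O)c1ccc(-n2ncc3c2/C(=C/CNC(=O)NS(=O)(=O)c2cc(Cl)c(Cl)s2)CCC3)cc1` gives 1 nM and stands lowest of the three numbers, beyond the scatter from both compound 1 and compound 2.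

Compound 4 `O=C(NC/C=C1\CCCc2cnn(Cc3ccc(Cl)cc3Cl)c21)NS(=O)(=O)c1cc(Cl)c(Cl)s1` is reached from compound 3 by 2,4-dichlorobenzyl in place of 4-(methylsulfonyl)phenyl on an aromatic nitrogen. Within the data shown here, no measured step bears directly on this change: compound 3 differs from compound 1 in two places at once, and the step from compound 1 to compound 2 concerns the sulfonyl-bearing ring, not the aromatic nitrogen. Compound 4 thus combines the 2,4-dichlorobenzyl of compounds 1 and 2 with the sulfonyl-bearing part of compound 3. The author therefore expects a step for this assay of a 2.0-fold higher number from compound 3 to compound 4 (0.30 log units; within the scatter) in either direction, most likely within the scatter, and estimates for compound 4 a value of 2 nM, between 0.7 nM and 6 nM.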

Compound 4, inhibition constant: 0.5 nM
Compound 4: middle estimate off by 4.0-fold (0.60 log units), on the high side; the measured number lies below the stated range.
By their numbers in this assay, from the lowest: compounds 4 and 3 (each within the scatter of the next); then compound 1; then compound 2.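

In this assay, the exchange on the aromatic nitrogen gives a 2.0-fold lower number from compound 3 to compound 4 (0.30 log units; within the scatter), so with 4,5-dichlorothiophen-2-yl on the sulfonyl sulfur, these two groups on the nitrogen cannot be told apart. With 2,4-dichlorobenzyl on the nitrogen, 4,5-dichlorothiophen-2-yl on the sulfonyl sulfur gives an 8.0-fold lower number from compound 1 to compound 4 (0.90 log units; beyond the scatter) in place of 4-chlorophenyl and a 20-fold lower number from compound 2 to compound 4 (1.30 log units; beyond the scatter) in place of 4-methoxyphenyl, so among these compounds the sulfonyl sulfur is where a change in group moves the number beyond the scatter. No supporting evidence is available to account for these steps.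

The compounds shown leave open what an unsubstituted thiophen-2-yl on the sulfonyl sulfur or a plain benzyl on the aromatic nitrogen would give. They also leave open whether the two nitrogen groups stay within the scatter of each other with 4-chlorophenyl on the sulfonyl sulfur.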